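Removing the phenyl from the ring nitrogen of compound 1

This account rests on a few compounds, and the source may have more. Where it says the series, first, only, none or still open, it means among the compounds named here.

Of the compounds shown here, three with a shared core have been measured in a functional assay on DU-145 cells (Homo sapiens) for antiproliferative activity, read by sulforhodamine B assay, with a stated time of 72 h; on this read-out lower numbers stand for stronger inhibition and higher numbers for weaker inhibition. Compound 1 `O=C1CS/C(=N/Nc2nncc3ccccc23)N1c1ccccc1` gives 97 nM in this assay, the highest of the three numbers. Compound 2 `O=S(=O)(Nc1ccccn1)c1ccc(Nc2nncc3ccccc23)cc1` gives 54 nM in this assay, and its gap to compound 1 lies within the usual scatter, so no order between these two is claimed. Compound 3 `COc1ccc(NC(=S)NNc2nncc3ccccc23)cc1` gives 25 nM in this assay, and its gap to compound 1 lies beyond the scatter, so compound 1 inhibits less strongly than compound 3.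

Compound 4 `O=C1CS/C(=N/Nc2nncc3ccccc23)N1` has not yet been measured. It differs from compound 1 in one place: hydrogen in place of phenyl on an amide-type nitrogen in a ring. Among the compounds with values here, no measured pair differs by a change of this kind, so the size of the step has no anchor in the data. The working expectation is that the step of a 2.6-fold higher number from compound 1 to compound 4 (0.41 log units; beyond the scatter) goes toward a higher number, meaning weaker inhibition, and is of modest size. For compound 4 the estimate in this assay is 250 nM, with a range from 80 nM to 900 nM. A number near that of compound 1 would not be surprising.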

Compound 4, half-maximal inhibitory concentration: 67 nM
Estimate against measurement, compound 4: 3.7-fold (0.57 log units) above; measured number outside the range, below it.
By their numbers in this assay, from the lowest: compound 3; then compounds 2, 4 and 1 (each within the scatter of the next).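

In this assay the replacement of phenyl by hydrogen on the amide-type nitrogen in the ring gives a 1.4-fold lower number from compound 1 to compound 4 (0.16 log units; within the scatter) as the first step read at this position. The phenyl, with its six carbon atoms, is therefore not needed to hold the number of compound 4 at 67 nM in this assay, and the two compounds cannot be ordered. No measurement shown here accounts for this result.

Only hydrogen and phenyl are shown on this nitrogen, so it remains open whether a methyl, a longer chain such as n-butyl, or a benzyl would also stay within the scatter of compound 1. A phenyl carrying a methoxy or a carboxylic acid group at this nitrogen is likewise an open case.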